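Methyl for Hydrogen on the Chain: An Expected Step

A few compounds are considered here, and "the series" means these few. Any claim that something is new, unique, unknown or untested is made for them only; others in the source may bear on it.

Compound 1 `CCOC(=O)N1N=C(c2cccc(OC)c2)CC1c1cc(OC)c(OC)c(OC)c1` and compound 2 `CCCOC(=O)N1N=C(c2cccc(OC)c2)CC1c1cc(OC)c(OC)c(OC)c1` share one core and differ by methyl in place of hydrogen on a saturated chain carbon, two bonds along the chain from an oxygen next to a carbonyl group. In a functional assay on MDA-MB-231 cells (Homo sapiens) for antiproliferative activity, read by MTT assay, with a stated time of 48 h (a higher number here means a weaker inhibitor of growth, a lower number a stronger inhibitor of growth), compound 1 gives 9100 nM and compound 2 gives 12500 nM, which is a 1.4-fold higher number from compound 1 to compound 2 (0.14 log units; within the scatter). Compound 3 `CCOC(=O)N1N=C(c2cccc(O)c2)CC1c1cc(OC)c(OC)c(OC)c1` differs from compound 1 by hydrogen in place of methyl on an oxygen on an aromatic ring; in this assay compound 3 gives 4710 nM, a step of a 1.9-fold lower number from compound 1 to compound 3 (0.29 log units; within the scatter). Compound 4 `CCCOC(=O)N1N=C(c2cccc(O)c2)CC1c1cc(OC)c(OC)c(OC)c1` differs from compound 3 by methyl in place of hydrogen on a saturated chain carbon, two bonds along the chain from an oxygen next to a carbonyl group, the same change as from compound 1 to compound 2, at the same place. For the measured compounds named here, only that one earlier pair shows what this change does, so the expectation rests on a single example. The expected step is a 1.4-fold higher number from compound 3 to compound 4 (0.14 log units; within the scatter), because the earlier pair gave a 1.4-fold higher number from compound 1 to compound 2 (0.14 log units; within the scatter). For compound 4 the estimate in this assay is 6500 nM, with a range from 3000 nM to 14000 nM.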

Compound 4, concentration for 50% growth inhibition: 10000 nM
Estimate against measurement, compound 4: 1.5-fold (0.19 log units) below; the measured number falls inside the stated range.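

The change from ethoxy to propoxy on the core of compound 3 gives a 2.1-fold higher number from compound 3 to compound 4 (0.33 log units; beyond the scatter), and in this assay the two steps for this change do not differ beyond the scatter: the same change on two cores in this assay, a 1.4-fold higher number (0.14 log units; within the scatter) from compound 1 to compound 2 and a 2.1-fold higher number (0.33 log units; beyond the scatter) from compound 3 to compound 4, 1.5-fold (0.19 log units) apart, within the scatter of two such steps. The other change, hydrogen in place of methyl on an oxygen on an aromatic ring, gives a 1.3-fold lower number from compound 2 to compound 4 (0.10 log units; within the scatter), and its two steps also agree within the scatter: the same change on two cores in this assay, a 1.9-fold lower number (0.29 log units; within the scatter) from compound 1 to compound 3 and a 1.3-fold lower number (0.10 log units; within the scatter) from compound 2 to compound 4, 1.5-fold (0.19 log units) apart, within the scatter of two such steps. So each change reads alike on the two cores shown, but two cores cannot show that this holds across the series, and these numbers do not explain why.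

On these data alone, it stays open whether a longer chain such as butoxy would continue the trend set by ethoxy and propoxy. As far as these compounds go, it also stays open how an amine on the aromatic ring, in place of the hydroxy or methoxy group, would compare.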